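The compounds below may be only part of what the source reports. "The series", "measured", "known", "first", "only" and "open" are said of these compounds alone.

Measured so far:
compound 1, `c1ccc(-c2cn3ccnc3c(-c3ccc4ncn(C5CCCCC5)c4c3)n2)cc1`: 54.4%
compound 2, `COc1ccc(-c2cn3ccnc3c(-c3ccc4ncn(C5CCCCC5)c4c3)n2)cc1`: 97.4%

Both numbers come from a functional assay on MDA-MB-468 cells (Homo sapiens) for inhibition, read by sulforhodamine B assay, with a stated time of 48 h, tested at 10 uM; on this read-out lower numbers stand for less inhibition and higher numbers for more inhibition at the one concentration tested (going by the name of the read-out). Within the data shown here, of the two, compound 2 stands highest: its only neighbour is compound 1, and the step of a number 43 percentage points higher from compound 1 to compound 2 (beyond the scatter) lies beyond the scatter, so the gap between them is real. Compound 3, `Fc1ccc(-c2cn3ccnc3c(-c3ccc4ncn(C5CCCCC5)c4c3)n2)cc1`, has not been measured. It differs from compound 2 in one place: fluoro in place of methoxy on an aromatic carbon. Among the measured compounds shown here, no measured step swaps one group for another on this ring; the only measured step, from hydrogen to methoxy, is a number 43 percentage points higher from compound 1 to compound 2 (beyond the scatter), large and upward. That step shows that a group on this aromatic carbon can move the number a long way, but it says nothing about whether fluoro will give a number nearer to that of compound 2 or nearer to the bare hydrogen of compound 1. The expectation for compound 3 therefore sits between the two measured values, with a wide range, and the expected step of a number 25.4 percentage points lower from compound 2 to compound 3 (beyond the scatter) in this assay points downward. The estimate for compound 3 is 72%, from 42% to 95%.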

Compound 3, a percentage reported as inhibition, at one concentration (the size of the read-out at that concentration, not a potency): 19.5%
For compound 3 the middle estimate is 52.5 percentage points above the measured one, outside the stated range (below it).
By their numbers in this assay, from the lowest: compound 3; then compound 1; then compound 2.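

Replacing the hydrogen of the phenyl ring with fluoro, para to a large group, gives a number 34.9 percentage points lower from compound 1 to compound 3 (beyond the scatter) in this assay, while replacing methoxy with fluoro gives a number 77.9 percentage points lower from compound 2 to compound 3 (beyond the scatter). The position therefore works in both directions: compound 1, with plain hydrogen, sits in the middle, methoxy in compound 2 raises the number, and fluoro in compound 3 lowers it, so a group here does not simply add inhibition and the choice of group decides the direction. Nothing available explains why these two groups pull in opposite directions, so the cause of this split remains unknown.

With only hydrogen, methoxy and fluoro at this position, three compounds cannot show what feature of a group sets the direction, and a hydroxyl, a methyl, a chloro, an ethoxy or an amine could each fall on either side of compound 1. These numbers also come from a single concentration, so they leave open how the three compounds would compare across a range of concentrations, and whether the same order would hold on other cells.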